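Aryl Replaces Isopropyl on the Imidazole Ring Nitrogen

This account rests on a few compounds, and the source may have more. Where it says the series, first, only, none or still open, it means among the compounds named here.

Measured compounds:
compound 1, `COc1cc(-c2nccn2C(C)C)cc(OC)c1OC` — > 100000 nM
compound 2, `COc1cc(-c2nccn2S(=O)(=O)c2ccc(C)cc2)cc(OC)c1OC` — > 100000 nM
compound 3, `COc1ccc(-n2ccnc2-c2cc(OC)c(OC)c(OC)c2)cc1[N+](=O)[O-]` — 600 nM

In a functional assay on HT-29 cells (Homo sapiens) for antiproliferative activity, read by MTT assay, with a stated time of 72 h (on this read-out lower numbers stand for stronger inhibition and higher numbers for weaker inhibition), compound 1 gives > 100000 nM, which is a limit of the assay and not a number. Compound 2 likewise gives only a limit, > 100000 nM. Within the data shown here, compound 3 is the one compound here with a number, giving 600 nM. Compound 1 therefore stands among the values that sit at the limit of > 100000 nM in this assay, at which 2 of the 3 values shown sit.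

Compound 4, `COc1cc(-c2nccn2-c2ccc(Br)cc2)cc(OC)c1OC`, has not been measured in this assay. It differs from compound 1 in one place: 4-bromophenyl in place of isopropyl on an aromatic nitrogen.

Among the measured compounds shown here, no step between two measured compounds is available to calibrate this change. For the measured compounds named here, compound 3, the only compound here that gives a number, also carries a six-membered carbon ring on the ring nitrogen, and with 600 nM it points to measurable inhibition for compound 4. The step of an at least 66-fold lower number from compound 1 to compound 4 (1.82 log units; beyond the scatter) is therefore expected to be large and toward stronger inhibition. Compound 4 is estimated at 1500 nM, with a range of 300 nM to 15000 nM.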

Compound 4, half-maximal inhibitory concentration: 7700 nM
Compound 4: the middle estimate sits 5.1-fold (0.71 log units) below what was measured; the range from low to high includes it.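

In this assay, 4-bromophenyl in place of isopropyl on the aromatic nitrogen gives an at least 12-fold lower number from compound 1 to compound 4 (1.11 log units; beyond the scatter), which shows that this position can turn the inactive-looking compound 1 into one with a measurable value. On these data alone, the true size of this step stays unknown, for compound 1 stands at a limit of the assay and not at a number: the limit of > 100000 nM in this assay, at which 2 of the 4 values shown sit. Compound 4 also shows that a ring with a single bromine is enough to give a number at this position, without the nitro and methoxy groups of compound 3.

The compounds shown leave open what the bromine itself contributes, and whether a plain phenyl or a phenyl carrying an amine or a carboxylic acid would serve on this nitrogen. They also leave open whether a longer chain without a ring would do.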